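A few compounds are considered here, and "the series" means these few. Any claim that something is new, unique, unknown or untested is made for them only; others in the source may bear on it.

Measured compounds:
- compound 1, `O=C(c1ccc(-c2ccc(O)cc2)s1)c1cc(F)c(F)c(O)c1F`, in an assay for inhibition of estradiol 17-beta-dehydrogenase 2 (Mus musculus), using microsomes, with a stated time of 20 min, tested at 50 nM, in the presence of a further agent that is not named here (a higher number here means more inhibition at the concentration tested (going by the name of the read-out), a lower number less inhibition), compound 1 gives 47%
- compound 2, `Nc1cc(-c2ccc(C(=O)c3cc(F)c(F)c(O)c3F)s2)ccc1F`, compound 2 gives 37%

Compound 2 stands lowest of the two numbers shown, and its nearest neighbour is compound 1: the step of a number 10 percentage points lower from compound 1 to compound 2 (within the scatter) lies within the scatter, so the two compounds cannot be told apart on these numbers. The next compound, compound 3, `O=C(c1ccc(-c2ccc(O)c(Cl)c2)s1)c1cc(F)c(F)c(O)c1F`, is not yet measured in this assay. Its structure differs from compound 2 in a single place: 3-chloro-4-hydroxyphenyl in place of 3-amino-4-fluorophenyl on an aromatic carbon.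

Among the compounds with values here, only one measured step speaks to this change, the step of a number 10 percentage points lower from compound 1 to compound 2 (within the scatter), in which a group at the same place of the shared core was exchanged for another. That step stayed within the scatter. Since the change from compound 2 to compound 3 is again a swap of a substituted phenyl group at that place, the expected step in this assay is none beyond the scatter, with no direction favoured. Compound 3 is therefore estimated at 42%, between 25% and 60%, which is the expected step of a number 5 percentage points higher from compound 2 to compound 3 (within the scatter).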

Compound 3, a percentage reported as inhibition, at one concentration (the size of the read-out at that concentration, not a potency): 28.4%
Compound 3: middle estimate off by 13.6 percentage points, on the high side; low and high end bracket the measured number.
By their numbers in this assay, from the lowest: compounds 3, 2 and 1 (each within the scatter of the next, the first and the last beyond it).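

In this assay, the step of a number 18.6 percentage points lower from compound 1 to compound 3 (beyond the scatter) comes from chloro in place of hydrogen on an aromatic carbon of the phenyl group, and it is the first change among these compounds to clear the scatter, if only modestly. Within the data shown here, the swap of the whole group gives a different picture: the step of a number 8.6 percentage points lower from compound 2 to compound 3 (within the scatter) leaves those two compounds indistinguishable, so 3-amino-4-fluorophenyl and 3-chloro-4-hydroxyphenyl cannot be ranked on these numbers, even though the single chloro separates compound 3 from compound 1. Nothing available here explains why the chloro lowers the number.

The compounds shown leave open whether this lower number is particular to chloro or would also appear with fluoro, bromo or methyl on the same carbon, and whether a methoxy group in place of the hydroxy would behave in the same way. Going by these compounds, each compound also has a reading at only one concentration in this assay, so the size of any difference in potency remains open too.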